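The source may hold more compounds than are shown below. What is called first, only, known or untested is meant among the compounds shown, and "the series" means these compounds.

Measured compounds in a functional assay on MGC-803 cells (Homo sapiens) for cytotoxicity, read by MTT assay, with a stated time of 72 h; a lower number here means a stronger inhibitor, a higher number a weaker inhibitor:
compound 1, `Cc1ccc(Cn2cc(CSC(=S)N3CCN(C(=O)NC(C)C)CC3)nn2)cc1`, gives 16600 nM.
compound 2, `CCN(C)C(=O)N1CCN(C(=S)SCc2cn(Cc3ccc(C)cc3)nn2)CC1`, gives 8270 nM.
compound 3, `COc1cc(Cn2cc(CSC(=S)N3CCN(C(=O)NC(C)C)CC3)nn2)cc(OC)c1OC`, gives no number but a limit, > 128000 nM.

Compounds 1 and 2 share one core and differ only by ethyl(methyl)amino in place of isopropylamino on a carbonyl carbon, which gives a 2.0-fold lower number from compound 1 to compound 2 (0.30 log units; within the scatter). Compound 3 carries a different core; how its core differs from that of compound 1 is not broken down here. For compound 3 only a limit is known, and it sits at the limit of > 128000 nM in this assay, at which 1 of the 3 values shown sits.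

Compound 4, `CCN(C)C(=O)N1CCN(C(=S)SCc2cn(Cc3cc(OC)c(OC)c(OC)c3)nn2)CC1`, is not yet measured. It differs from compound 3 by ethyl(methyl)amino in place of isopropylamino on a carbonyl carbon. The surroundings of the place are the same in both pairs, so this is the same change as from compound 1 to compound 2. For compound 4 the expected step is a step that the limit leaves unreadable from compound 3 to compound 4, by analogy with a 2.0-fold lower number from compound 1 to compound 2 (0.30 log units; within the scatter). As compound 3 stands only at a limit, any estimate for compound 4 rests on that limit and is loose. Compound 4 is estimated at 150000 nM, between 50000 nM and 400000 nM, and it is expected that this assay may again report only a limit for compound 4.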

Compound 4, half-maximal inhibitory concentration: 85700 nM
For compound 4 the middle estimate is 1.8-fold (0.24 log units) above the measured one; low and high end bracket the measured number.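

The replacement of isopropylamino by ethyl(methyl)amino on a carbonyl carbon, carried onto the core of compound 3, gives in this assay an at least 1.4-fold lower number from compound 3 to compound 4 (0.17 log units; that floor lies within the scatter). Set beside the earlier step, this reading does not conflict with it, but neither step is shown to lie beyond the scatter, and the size of the second remains unfixed: the same change on two cores in this assay, a 2.0-fold lower number (0.30 log units; within the scatter) from compound 1 to compound 2 and an at least 1.4-fold lower number (0.17 log units; that floor lies within the scatter) from compound 3 to compound 4; the limit leaves it open whether they differ
Compound 3 stands only at a limit, > 128000 nM, so the data fit a change that carries over between the two cores but do not show that its size is the same on both.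

Left open is how the change reads on a further core where both partners give a number, and whether the step there would exceed the scatter. Also open, as far as these compounds go, is what a longer-chain amine such as dibutylamino, or a cyclic amine such as morpholine, would give on the same carbonyl carbon in this assay.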